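Chain substituent swap on the shared core

The compounds below may be only part of what the source reports. "The series", "measured", "known", "first", "only" and "open" are said of these compounds alone.

Among the compounds with values here, compound 2 `CNS(=O)(=O)NC[C@@H]1CCCc2cc(S(=O)(=O)c3cccc(F)c3)ccc21` sits at the higher of the two numbers measured so far in an assay on isolated protein for displacement of a labelled ligand from 5-hydroxytryptamine receptor 6 (Homo sapiens) (a higher number here means a weaker inhibitor, a lower number a stronger inhibitor), where compound 2 gives 1 nM. Within the data shown here, its nearest neighbour is compound 1 `COc1cccc(S(=O)(=O)c2ccc3c(c2)CCC[C@H]3CN)c1`, which in this assay gives 0.398 nM; the gap between the two lies beyond the usual scatter, and no single-point step between them is recorded, so only the two values themselves can be set side by side.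

Compound 3 `N=C(N)NC(=O)C[C@@H]1CCCc2cc(S(=O)(=O)c3cccc(F)c3)ccc21` has not yet been measured. It differs from compound 2 as follows: a group of 6 heavy atoms (2 carbon, 3 nitrogen, 1 oxygen; no ring) in place of a group of 6 heavy atoms (1 carbon, 2 nitrogen, 2 oxygen, 1 sulfur; no ring), on a saturated chain carbon bound to a saturated ring carbon. Among the measured compounds shown here, no measured pair isolates this change, so the expectation rests on the two values alone. In this assay a small step is expected, a 2.0-fold higher number from compound 2 to compound 3 (0.30 log units; within the scatter), towards a higher number and not clearly beyond the scatter. Compound 3 is estimated at 2 nM in this assay, within 0.5 nM to 8 nM.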

Compound 3, inhibition constant: 0.631 nM
For compound 3 the middle estimate is 3.2-fold (0.50 log units) above the measured one; the range from low to high includes it.
By their numbers in this assay, from the lowest: compounds 1, 3 and 2 (each within the scatter of the next, the first and the last beyond it).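

On the saturated chain carbon bound to a saturated ring carbon, putting a group of 6 heavy atoms (2 carbon, 3 nitrogen, 1 oxygen) in place of (methylsulfamoyl)amino gives, in this assay, a 1.6-fold lower number from compound 2 to compound 3 (0.20 log units; within the scatter). This first step read at this place shows that the two groups cannot be told apart here, so the sulfur of the leaving group is not needed to keep the number in this range. Nothing at hand bears on why the two groups read alike.

From the compounds shown here alone, whether a simple amine, a carboxylic acid or a longer chain at this place on the core of compound 2 would also stay in this range remains open. Compound 1 differs from compound 2 and compound 3 in more than one place, so its value cannot be assigned to any single change.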